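Statin-type inhibitors: amide substitution and reductase inhibition

A few compounds are considered here, and "the series" means these few. Any claim that something is new, unique, unknown or untested is made for them only; others in the source may bear on it.

Compound 1 `CC(C)c1c(C(=O)NCc2cccc(F)c2F)nn(-c2ccc(F)cc2)c1OC[C@@H](O)C[C@@H](O)CC(=O)O`: 2 nM
Compound 2 `Cc1cccc(CNC(=O)c2nn(-c3ccc(F)cc3)c(OC[C@@H](O)C[C@@H](O)CC(=O)O)c2C(C)C)c1`: 4.9 nM

Both compounds share one core and were measured in an assay on microsomes from liver for inhibition of 3-hydroxy-3-methylglutaryl-coenzyme A reductase (Rattus norvegicus); a higher number here means a weaker inhibitor, a lower number a stronger inhibitor. Compound 2 gives the higher of the two numbers, and its nearest neighbour is compound 1, with the step of a 2.5-fold higher number from compound 1 to compound 2 (0.39 log units; beyond the scatter).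

Compound 3 `CC(C)c1c(C(=O)N(C)Cc2ccc(F)cc2)nn(-c2ccc(F)cc2)c1OC[C@@H](O)C[C@@H](O)CC(=O)O` differs from compound 2 in the amide portion: (4-fluorobenzyl)(methyl)amino in place of (3-methylbenzyl)amino on a carbonyl carbon.

Going by the values given here, the only measured step that bears on this change is a 2.5-fold higher number from compound 1 to compound 2 (0.39 log units; beyond the scatter), which shows that exchanging one benzyl substituent for another shifts the number modestly. Among the compounds with values here, compound 3 brings a fluorine back onto the benzyl ring but also replaces the amide hydrogen with a methyl group, and no measured pair here shows what that second change does. As far as these compounds go, the ring change alone would suggest a number near that of compound 1, but the loss of the hydrogen-bond donor is untested, so the estimate is held wide and centred near compound 2.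

Compound 3 is expected at 7 nM, between 2 nM and 30 nM, a step of a 1.4-fold higher number from compound 2 to compound 3 (0.15 log units; within the scatter) that may well fall within the scatter.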

Compound 3, half-maximal inhibitory concentration: 18 nM
Compound 3: middle estimate off by 2.6-fold (0.41 log units), on the low side; measured number inside the range.
By their numbers in this assay, from the lowest: compound 1; then compound 2; then compound 3.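

In this assay, the change to (4-fluorobenzyl)(methyl)amino on the carbonyl carbon gives a 3.7-fold higher number from compound 2 to compound 3 (0.57 log units; beyond the scatter), and the comparison with the difluorinated amide gives a 9.0-fold higher number from compound 1 to compound 3 (0.95 log units; beyond the scatter), so compound 3 stands apart from both earlier compounds and has the highest number of the three. The two compounds that keep the amide hydrogen have the lower numbers, yet the step to compound 3 also moves the ring fluorine and adds a methyl group on the nitrogen, so this single step cannot divide the shift between those changes. No supporting measurement is available to explain the shift.

The compounds shown leave open how much of the step belongs to the methyl group on the nitrogen and how much to the ring substituent, a question that (4-fluorobenzyl)amino and (3-methylbenzyl)(methyl)amino on the same carbonyl carbon would address directly. They also leave open whether a longer chain on that nitrogen, such as the ethyl group in (4-fluorobenzyl)(ethyl)amino, would move the number further.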